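Swapping Isopropyl for Trifluoroethyl in a Low-Clearance Series

The compounds below may be only part of what the source reports. "The series", "measured", "known", "first", "only" and "open" are said of these compounds alone.

In an in vivo ADME assay on the whole organism (plasma, strain Sprague-Dawley) for pharmacokinetics, with Rattus norvegicus as the target (on this read-out higher numbers stand for fast clearance and lower numbers for slow clearance), compound 2 `Cc1cc(CCC(=O)O)ccc1-c1noc(-c2ccc(OC(C)C)c(C#N)c2)n1` has the lower of the two measured numbers at 2.3 mL/min/kg, while compound 1 `Cc1cc(CCC(=O)O)ccc1-c1noc(-c2ccc(OC(C)C)c(Cl)c2)n1` gives 5.7 mL/min/kg. Compound 3 `Cc1cc(CCC(=O)O)ccc1-c1noc(-c2ccc(OCC(F)(F)F)c(C#N)c2)n1` keeps the nitrile of compound 2 and carries 2,2,2-trifluoroethyl in place of isopropyl on an oxygen on an aromatic ring. Among the measured compounds shown here, only one measured step is available, a 2.5-fold lower number from compound 1 to compound 2 (0.39 log units; beyond the scatter), a modest change with cyano in place of chloro on an aromatic carbon. For the measured compounds named here, it bears only indirectly, since it lies elsewhere on the molecule, and no measured pair varies the isopropyl group. From the compounds shown here alone, no step beyond the scatter is therefore expected in this assay, and the direction remains open. The expected change is a 1.1-fold higher number from compound 2 to compound 3 (0.04 log units; within the scatter). For compound 3 the estimate is 2.5 mL/min/kg, with an expected range from 1 mL/min/kg to 6 mL/min/kg.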

Compound 3, clearance: 1.2 mL/min/kg
For compound 3 the middle estimate is 2.1-fold (0.32 log units) above the measured one, within the range that was stated.
By their numbers in this assay, from the lowest: compounds 3 and 2 (each within the scatter of the next); then compound 1.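

Among the compounds shown here, the pair of compound 2 and compound 3 is the first to vary the group on this oxygen. In this assay, 2,2,2-trifluoroethyl in place of isopropyl on an oxygen on an aromatic ring gives a 1.9-fold lower number from compound 2 to compound 3 (0.28 log units; within the scatter), so with the nitrile kept, the exchange leaves the read-out within the usual scatter and both compounds remain low-clearance members of the series. No measurement offered here accounts for this result.

From the compounds shown here alone, this single pair carries the nitrile alone, so it remains open whether the exchange would read the same with chloro in that place. Going by these compounds, it also remains open how clearance would respond to a different group on the oxygen, such as a cyclopropylmethyl group or a longer chain like n-butyl.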